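From Methyl to 3-Methylphenyl on the Ring Nitrogen

The source may report more compounds than this note shows. Statements on the series, on what has been measured and on what is new or still open speak of the compounds shown alone.

Compound 1 `COc1cc(-c2nccn2C)cc(OC)c1OC` is the starting point. In a functional assay on HeLa cells (Homo sapiens) for antiproliferative activity, read by MTT assay, with a stated time of 72 h (on this read-out higher numbers stand for weaker inhibition and lower numbers for stronger inhibition), compound 1 gives > 100000 nM, which is a limit of the assay rather than a number. Compound 2 `CCCCCn1ccnc1-c1cc(OC)c(OC)c(OC)c1` has butyl in place of hydrogen on a saturated chain carbon bound to an aromatic nitrogen. In this assay compound 2 gives > 100000 nM, again a limit. The step that the two limits leave unreadable from compound 1 to compound 2 therefore cannot be read, as the limit of > 100000 nM in this assay, at which 2 of the 2 values shown sit, shows. Compound 3 `COc1cc(-c2nccn2-c2cccc(C)c2)cc(OC)c1OC` differs from compound 1 by 3-methylphenyl in place of methyl on an aromatic nitrogen. For the measured compounds named here, no measured step covers this kind of change, and the single recorded step is unreadable, so nothing points to a shift in either direction beyond the scatter. Compound 3 is therefore expected to sit near the same limit, with an estimated step of an at least 1.2-fold lower number from compound 1 to compound 3 (0.09 log units; that floor lies within the scatter) that carries wide uncertainty, and its estimated value is 80000 nM, between 15000 nM and 300000 nM.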

Compound 3, half-maximal inhibitory concentration: 1900 nM
For compound 3 the middle estimate is 42-fold (1.62 log units) above the measured one, outside the stated range (below it).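

The aromatic nitrogen of the shared core now proves able to change the read-out, something the methyl and pentyl compounds could not show. In this assay compound 3 gives 1900 nM as a true number, and replacing methyl with 3-methylphenyl is an at least 52-fold lower number from compound 1 to compound 3 (1.72 log units; beyond the scatter) while replacing pentyl with 3-methylphenyl is an at least 52-fold lower number from compound 2 to compound 3 (1.72 log units; beyond the scatter) on the same nitrogen. These steps give only minimum sizes, because neither starting compound has an exact value: the limit of > 100000 nM in this assay, at which 2 of the 3 values shown sit.

With only one ring-bearing group shown, it remains open whether the drop comes from the six-membered aromatic ring alone or also needs its methyl group. A plain phenyl, a benzyl or a 3-chlorophenyl group on this nitrogen would help to separate these possibilities.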